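The source may report more compounds than this note shows. Statements on the series, on what has been measured and on what is new or still open speak of the compounds shown alone.

Working notes on the series. In an ADME assay on microsomes from liver (Homo sapiens) for metabolic stability, read by mass spectrometry, using NADPH, with a stated time of 10 min (on this read-out higher numbers stand for a more stable compound and lower numbers for a less stable compound), three compounds have numbers: compound 1 `CCCCc1[nH]c(=O)c(-c2n[nH]c(Cc3ccccc3)n2)c(O)c1-c1c(OC)cccc1OC` sits low (36%), compound 3 `CCCCc1[nH]c(=O)c(C(=O)OCC)c(O)c1-c1c(OC)cccc1OC` sits high (89%), and compound 2 `COc1cccc(OC)c1-c1c(C2CC2)[nH]c(=O)c(-c2nnc(Cc3ccc(Cl)cc3)o2)c1O` gives 88% as the second of the three numbers. That places compound 2 within the scatter of compound 3 and beyond the scatter from compound 1. Within the data shown here, no two measured compounds differ in one place only, so no single change has a measured size yet.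

Compound 4 `CCCCc1[nH]c(=O)c(-c2nnc(Cc3ccc(Cl)cc3)o2)c(O)c1-c1c(OC)cccc1OC` is the next entry. It differs from compound 2 by butyl in place of cyclopropyl on an aromatic carbon. Compound 1 and compound 3 both carry butyl, but on different cores. The expectation leans on compound 1 (36%), while compound 3 (89%) goes against it, so the range stays wide. A fall beyond the scatter is expected in this assay (estimated step: a number 20 percentage points lower from compound 2 to compound 4 (beyond the scatter)). The estimate for compound 4 is 68% (expected range 42% to 90%).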

Compound 4, percent of the compound remaining in the Homo sapiens assay: 66%
For compound 4 the middle estimate is 2 percentage points above the measured one, within the range that was stated.
By their numbers in the Homo sapiens assay, from the lowest: compound 1; then compound 4; then compounds 2 and 3 (each within the scatter of the next).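

Butyl in place of cyclopropyl, on an aromatic carbon next to the ring nitrogen, is the first single change in the series with a measured size: in the Homo sapiens assay it gives a number 22 percentage points lower from compound 2 to compound 4 (beyond the scatter) on the shared core. In a physicochemical assay for solubility, in phosphate buffer, with a stated time of 24 h, at pH 7.4 (on this read-out lower numbers stand for lower solubility and higher numbers for higher solubility), the same change comes with lower solubility: the measured solubility of compound 2, 12 ug/mL, and of compound 4, < 1 ug/mL, an at least 12-fold lower number (1.07 log units; beyond the scatter). In the physicochemical assay compound 2 gives 12 ug/mL. In the physicochemical assay compound 4 gives < 1 ug/mL, which is a limit of the assay and not a number.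

The compounds shown compare only these two groups at this position, so they do not separate the presence of the three-membered ring from the length of the chain. From the compounds shown here alone, how a propyl group, a longer chain or an amine at this position would read in either assay remains open, as does whether the step holds on other cores.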